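From Methoxy to Nitro: A Tolerance Question

The source may report more compounds than this note shows. Statements on the series, on what has been measured and on what is new or still open speak of the compounds shown alone.

Measured in an ADME assay on BHK-21 cells (Mesocricetus auratus) for cytotoxicity, read by MTT assay, with a stated time of 96 h; a higher number here means that more compound is tolerated, a lower number that less compound is tolerated:
Compound 1 (`Cc1ccc(/N=N/N(C)c2ccccc2)cc1`): > 100000 nM (a limit)
Compound 2 (`COc1ccc(/N=N/N2CCCC2)cc1`): >= 100000 nM (a limit)

Neither measured compound has a number in this assay. Compound 1 reached only the limit > 100000 nM in this test. For the measured compounds named here, compound 2 likewise stands only at a limit, >= 100000 nM, and this is the sole reading for it.

Compound 3 (`O=[N+]([O-])c1ccc(/N=N/N2CCCC2)cc1`) keeps the core of compound 2 but carries nitro in place of methoxy on an aromatic carbon, para to a group of 7 heavy atoms (nitro in place of methoxy on an aromatic carbon). Going by the values given here, no measured step shows what such a change does in this assay, so any forecast rests on thin ground. A modest drop in the tolerated concentration is expected, although a second reading at the limit would fit the data equally well. The estimated change is an at least 1.6-fold lower number from compound 2 to compound 3 (0.22 log units; that floor lies within the scatter). Compound 3 is expected at 60000 nM, with an estimated range from 15000 nM to 100000 nM.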

Compound 3, half-maximal cytotoxic concentration: >= 100000 nM
Compound 3 gave a limit, no number (the forecaster's own chance of this, stated with the estimate: 55%); middle value at least 1.6-fold (0.22 log units) from the limit.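

For the compounds shown here, compound 2 and compound 3 both stand only at a limit in this assay, not at a number, and no step between them can be read. The compounds shown leave open whether nitro in place of methoxy on an aromatic carbon changes the tolerated concentration at all, and how much compound would prove too much for these cells.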